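Tertiary amide in place of the tert-butylamino group

The source may report more compounds than this note shows. Statements on the series, on what has been measured and on what is new or still open speak of the compounds shown alone.

Measured compounds:
Compound 1 `Cc1c(C(C)C)c(=O)on1C(=O)NC(C)(C)C` gives > 1000 nM in an assay (strain Wistar) for inhibition of Hormone-sensitive lipase (Rattus norvegicus), read by spectrophotometry; on this read-out higher numbers stand for weaker inhibition and lower numbers for stronger inhibition.
Compound 2 `Cc1c(C(C)C)c(=O)on1C(=O)Nc1ccccc1` gives > 1000 nM in this assay.
Compound 3 `Cc1c(C(C)C)c(=O)on1C(=O)N(C)c1ccccn1` gives 240 nM in this assay.

Compound 1 stands only at a limit of this assay, not at a number. The same is true of compound 2, so the step that the two limits leave unreadable from compound 1 to compound 2 cannot be read from the two values, a point summed up by the limit of > 1000 nM in this assay, at which 2 of the 3 values shown sit. Compound 3 is the only one of the three that yields a number, and it differs from compound 1 in more than one place, so its value cannot be traced to a single change.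

Compound 4 `Cc1c(C(C)C)c(=O)on1C(=O)N1CCCC1` is the next compound. Its difference from compound 1 is pyrrolidin-1-yl in place of (tert-butyl)amino on a carbonyl carbon. Both compound 3 and compound 4 carry a carbonyl nitrogen without a hydrogen, whereas compound 1 and compound 2 each carry one with a hydrogen; with a single numeric value among the three, this gives a hint rather than a measured step. For the measured compounds named here, no measured step therefore settles the size or direction of the change from compound 1 to compound 4.

Compound 4 is expected to fall at 600 nM, with a range from 150 nM to 3000 nM, and the expected step of an at least 1.6-fold lower number from compound 1 to compound 4 (0.22 log units; that floor lies within the scatter) is uncertain because compound 1 sits at the limit of > 1000 nM in this assay, at which 2 of the 3 values shown sit.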

Compound 4, half-maximal inhibitory concentration: 15 nM
Beside the measured number, compound 4's estimate is 40-fold (1.60 log units) above it, and the stated range ends above it.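

Placing pyrrolidin-1-yl in place of (tert-butyl)amino on a carbonyl carbon gives, in this assay, an at least 66-fold lower number from compound 1 to compound 4 (1.82 log units; beyond the scatter), so this position responds strongly to a swap between two groups with the same heavy-atom count. Compound 1 gives > 1000 nM, which is a limit and not a number, so the step is only a floor on the true size of the change: the limit of > 1000 nM in this assay, at which 2 of the 4 values shown sit.

The earlier compounds shown here offered only a hint, but this single change now ties the loss of the amide hydrogen and the arrival of a ring to much stronger inhibition, and it cannot tell those two features apart.

An open-chain diethylamino group, which also has no hydrogen on the nitrogen but no ring, would help separate the two features, while piperidin-1-yl or morpholin-4-yl would test how far the ring itself can change. The compounds shown also leave open whether the gain would hold with a different group in place of the methyl or isopropyl on the shared core.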